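The compounds below may be only part of what the source reports. "The series", "measured", "known", "first", "only" and "open" are said of these compounds alone.

Working notes on the series. Two compounds have a number in a functional assay on RMS13 cells for antagonist activity at Urotensin-2 receptor (Homo sapiens), read by FLIPR and calcium flux, with a stated time of 1 h; on this read-out lower numbers stand for stronger inhibition and higher numbers for weaker inhibition. Compound 1 `CCN1CCN(c2cccc3c2C(=O)N([C@H](CCCNS(=O)(=O)c2cn(C)c(C)n2)c2ccc(OC)c(OC)c2)C3=O)CC1` gives 810 nM in this assay. For the measured compounds named here, compound 2 `CCN1CCN(c2cccc3c2CN([C@H](CCCNC(=O)c2c(C)n[nH]c2C)c2ccc(OC)c(OC)c2)C3=O)CC1` gives 130 nM in this assay, the lower of the two numbers; the gap to compound 1 lies beyond the scatter, but the two differ in more than one place and no single step between them is worked out.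

Compound 3 `CCN1CCN(c2cccc3c2CN([C@H](CCCNS(=O)(=O)c2c[nH]cn2)c2ccc(OC)c(OC)c2)C3=O)CC1` is not yet measured. It differs from compound 2 in one place: (1H-imidazol-4-yl)sulfonyl in place of (3,5-dimethyl-1H-pyrazol-4-yl)carbonyl on an amine nitrogen. Compound 1 also carries a sulfonyl group on that amine nitrogen, though on a different core, so its value of 810 nM is only a loose pointer. For compound 3 a step toward a weaker number is expected, a 2.3-fold higher number from compound 2 to compound 3 (0.36 log units; beyond the scatter), of a size just beyond the scatter. Compound 3 is estimated at 300 nM in this assay, within a range of 80 nM to 1200 nM.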

Compound 3, half-maximal inhibitory concentration: 51 nM
Estimate against measurement, compound 3: 5.9-fold (0.77 log units) above, and the stated range ends above it.
By their numbers in this assay, from the lowest: compound 3; then compound 2; then compound 1.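

In this assay, for the compounds shown here, the change of (3,5-dimethyl-1H-pyrazol-4-yl)carbonyl to (1H-imidazol-4-yl)sulfonyl on the amine nitrogen gives a 2.5-fold lower number from compound 2 to compound 3 (0.41 log units; beyond the scatter) and is the first step that differs in one place. This position therefore accepts a sulfonyl link on the shared core without loss, and the number moves toward stronger inhibition. Compounds 1 and 2 differ in more than one place, so that pair could not show this. Nothing measured here bears on why the number falls.

Going by these compounds, the linker and the ring change together in this step, so the share of each stays open; (3,5-dimethyl-1H-pyrazol-4-yl)sulfonyl or (1H-imidazol-4-yl)carbonyl on the same nitrogen would separate them. Also open, on these data alone, is whether the step carries over to the core of compound 1.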